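The source may report more compounds than this note shows. Statements on the series, on what has been measured and on what is new or still open speak of the compounds shown alone.

Measured so far in a functional assay on MCF7 cells (Homo sapiens) for cytotoxicity, read by MTT assay, with a stated time of 48 h; on this read-out lower numbers stand for stronger inhibition and higher numbers for weaker inhibition:
- compound 1 `Cc1ccc(S(=O)(=O)/N=C(/CCNC2=CC(=O)c3ccccc3C2=O)Nc2cccc(C(F)(F)F)c2)cc1`: 89100 nM
- compound 2 `COc1ccc(N/C(CCNC2=CC(=O)c3ccccc3C2=O)=N\S(=O)(=O)c2ccc(C)cc2)c(OC)c1`: 30200 nM

Going by the values given here, compound 2 holds the lowest of the two numbers; the only neighbour is compound 1, and the change from compound 1 to compound 2 gives a 3.0-fold lower number from compound 1 to compound 2 (0.47 log units; beyond the scatter), a modest step arising from a 2,4-dimethoxyphenyl in place of a 3-(trifluoromethyl)phenyl on the amine nitrogen.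

The next compound, compound 3 `COc1cc(N/C(CCNC2=CC(=O)c3ccccc3C2=O)=N\S(=O)(=O)c2ccc(C)cc2)cc(OC)c1OC`, is not yet measured. It differs from compound 2 in one place: 3,4,5-trimethoxyphenyl in place of 2,4-dimethoxyphenyl on an amine nitrogen.

Among the compounds with values here, only one measured step touches this position, and it swaps a 3-(trifluoromethyl)phenyl for a methoxy-bearing aryl; no measured step exchanges one methoxy pattern for another. The step from compound 1 to compound 2 shows that the aryl group on the amine nitrogen can move this assay beyond the scatter, but it says nothing about the direction for a third methoxy group. In this assay a step from compound 2 to compound 3 of about a 1.2-fold lower number from compound 2 to compound 3 (0.08 log units; within the scatter) is therefore expected, which is within the scatter and carries no direction worth claiming. For compound 3 the estimate in this assay is 25000 nM, with a range of 8000 nM to 80000 nM.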

Compound 3, half-maximal inhibitory concentration: 3050 nM
Compound 3: middle estimate off by 8.2-fold (0.91 log units), on the high side, outside the stated range (below it).
By their numbers in this assay, from the lowest: compound 3; then compound 2; then compound 1.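

In this assay, the aryl group on the amine nitrogen carries more weight than the earlier pair suggested: moving between two methoxy-bearing aryl groups gives a 9.9-fold lower number from compound 2 to compound 3 (1.00 log units; beyond the scatter) and so exceeds the change seen on leaving 3-(trifluoromethyl)phenyl, a 3.0-fold lower number from compound 1 to compound 2 (0.47 log units; beyond the scatter) in that earlier pair. The presence of methoxy groups alone therefore does not settle the outcome at this position, since 2,4-dimethoxyphenyl and 3,4,5-trimethoxyphenyl give clearly separated numbers, although this single exchange alters both how many methoxy groups are present and where they stand. Taken across the whole position, the 3,4,5-trimethoxyphenyl group also gives a 29-fold lower number from compound 1 to compound 3 (1.47 log units; beyond the scatter) and places compound 3 lowest among the three compounds, with both of its steps beyond the scatter.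

Still open, going by these compounds, is how much of the change belongs to the number of methoxy groups and how much to their placement, and whether a hydroxy group or an amine on the phenyl ring in place of a methoxy group would keep the low number of compound 3. Going by these compounds alone, nothing measured so far accounts for the size of this change.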